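The source may report more compounds than this note shows. Statements on the series, on what has been measured and on what is new or still open speak of the compounds shown alone.

Measured compounds in an assay on HEK293 cells for displacement of a labelled ligand from 5-hydroxytryptamine receptor 7 (Rattus norvegicus), with a stated time of 60 min; on this read-out higher numbers stand for weaker inhibition and lower numbers for stronger inhibition:
compound 1 `c1ccc(Cn2cc(-c3ccccc3)c3c2CCNC3)cc1` — 220 nM
compound 2 `FC(F)(F)c1ccc(-c2cn(Cc3ccccc3)c3c2CNCC3)cc1` — 167 nM
compound 3 `O=[N+]([O-])c1ccc(-c2cn(Cc3ccccc3)c3c2CNCC3)cc1` — 450 nM

Compound 3 gives the highest number of the three and is thus the weakest inhibitor in this set: the step from compound 1 to it was a 2.0-fold higher number from compound 1 to compound 3 (0.31 log units; beyond the scatter), and the step from compound 2 to it was a 2.7-fold higher number from compound 2 to compound 3 (0.43 log units; beyond the scatter), both beyond the scatter. Between the other two the step was a 1.3-fold lower number from compound 1 to compound 2 (0.12 log units; within the scatter).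

Compound 4 `Fc1ccc(-c2cn(Cc3ccccc3)c3c2CNCC3)cc1` has not been measured. It differs from compound 3 in one place: fluoro in place of nitro on an aromatic carbon. Going by the values given here, no measured compound carries a fluoro group, so the steps that bear on this change are the two that brought in the nitro group, a 2.0-fold higher number from compound 1 to compound 3 (0.31 log units; beyond the scatter) and a 2.7-fold higher number from compound 2 to compound 3 (0.43 log units; beyond the scatter), each a modest rise in the number beyond the scatter. Taking the nitro group away is expected to reverse that rise, and a fluoro group is a small change from the unsubstituted compound 1, which gives 220 nM. A modest fall in the number in this assay is therefore expected, back toward the level of compound 1.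

The expected step is a 2.3-fold lower number from compound 3 to compound 4 (0.35 log units; beyond the scatter). For compound 4 the estimate is 200 nM, with a range from 90 nM to 450 nM.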

Compound 4, inhibition constant: 45 nM
For compound 4 the middle estimate is 4.4-fold (0.65 log units) above the measured one; measured number below the stated range.
By their numbers in this assay, from the lowest: compound 4; then compounds 2 and 1 (each within the scatter of the next); then compound 3.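

Until compound 4, a substituent at this position on the aromatic ring, para to a large group, had not lowered the number beyond the scatter in this assay: trifluoromethyl left it within the scatter and nitro raised it, whereas fluoro gives a clear fall from the unsubstituted compound (a 4.9-fold lower number from compound 1 to compound 4 (0.69 log units; beyond the scatter)). Fluoro also separates clearly from the two larger-named substituents at the same place (a 3.7-fold lower number from compound 2 to compound 4 (0.57 log units; beyond the scatter); a 10-fold lower number from compound 3 to compound 4 (1.00 log units; beyond the scatter)), which makes compound 4 the strongest inhibitor of the four and shows that the number depends on which group sits here, not merely on whether one does. Nothing available gives a reason for these steps.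

Whether the fall is particular to fluoro stays open, since the compounds shown include no chloro, methyl or methoxy group at this place and no fluoro group elsewhere on this ring. Also open, on these data alone, is whether the gain carries over when the benzyl group or the ring amine of the shared core is changed, as both stay the same across all four compounds.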